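Chain hydroxamate in place of aryl hydroxamate on compound 3

The compounds below may be only part of what the source reports. "The series", "measured", "known", "first", "only" and "open" are said of these compounds alone.

Measured compounds in an assay on isolated protein for inhibition of Nicotinamide phosphoribosyltransferase (Homo sapiens), read by fluorescence, with stated times of 5 min and 15 min; a higher number here means a weaker inhibitor, a lower number a stronger inhibitor:
compound 1 `O=C(/C=C/c1ccc(CN(Cc2ccc(F)cc2)c2ncc(C(=O)NCCCn3ccnc3)s2)cc1)NO` gives 14 nM
compound 2 `CC(C)CCN(CCCCCCC(=O)NO)c1ncc(C(=O)NCCCn2ccnc2)s1` gives 15 nM
compound 3 `O=C(NO)c1ccc(CN(Cc2ccc(F)cc2)c2ncc(C(=O)NCCCn3ccnc3)s2)cc1` gives 14 nM

Compound 3 stands level with compound 1, the two together giving the lowest numbers of the three, and compound 2 sits within the scatter of both. For the measured compounds named here, the one step with a record here, no change at the digits printed from compound 1 to compound 3 (within the scatter), shows that shortening the hydroxamate arm on the aromatic ring left this assay unchanged.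

Compound 4 `O=C(CCCCCCN(Cc1ccc(F)cc1)c1ncc(C(=O)NCCCn2ccnc2)s1)NO` differs from compound 3 by 5-(hydroxycarbamoyl)pentyl in place of 4-(hydroxycarbamoyl)phenyl on a saturated chain carbon bound to a nitrogen on an aromatic ring. Going by the values given here, no measured step covers this change directly; the nearest guide is compound 2, which carries its hydroxamate on an open chain from the same nitrogen and gives 15 nM. The step of a 1.4-fold higher number from compound 3 to compound 4 (0.15 log units; within the scatter) is therefore expected to be small. Compound 4 is estimated at 20 nM, with a range from 8 nM to 60 nM.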

Compound 4, half-maximal inhibitory concentration: 19 nM
Estimate against measurement, compound 4: 1.1-fold (0.02 log units) above; the range from low to high includes it.
By their numbers in this assay, from the lowest: compounds 1, 3, 2 and 4 (each within the scatter of the next).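

In this assay both a 1.4-fold higher number from compound 3 to compound 4 (0.13 log units; within the scatter) and a 1.4-fold higher number from compound 1 to compound 4 (0.13 log units; within the scatter) stay within the scatter when 5-(hydroxycarbamoyl)pentyl stands in place of an arm carrying an aromatic ring. At this place, then, the hydroxamate need not hang from a phenyl ring for the number to stay in this range. With the open chain kept, 4-fluorophenyl in place of isobutyl gives a 1.3-fold higher number from compound 2 to compound 4 (0.10 log units; within the scatter) as well. Nothing available here accounts for these level numbers. On these data alone, whether a longer chain, or a carboxylic acid in place of the hydroxycarbamoyl end, would hold this range stays open.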